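A few compounds are considered here, and "the series" means these few. Any claim that something is new, unique, unknown or untested is made for them only; others in the source may bear on it.

Measured so far:
Compound 1, `CSCCN(C(=O)c1c(O)c2cc(SC)ccc2n(C)c1=O)c1ccccc1`, gives 65% in a functional assay on the whole organism with Mus musculus as the target, at a dose of 32 mg/kg by the oral route; on this read-out lower numbers stand for less inhibition and higher numbers for more inhibition at the one dose given (going by the name of the read-out).
Compound 2, `CN1C(=O)/C(=C(/S)N(C)c2ccccc2)C(=O)c2cc(Cl)ccc21`, gives 100%.
Compound 3, `COc1ccc(N(C)/C(S)=C2/C(=O)c3cc(Cl)ccc3N(C)C2=O)cc1`, gives 97%.

Compound 3 stands second highest of these three numbers in this assay: compound 2 lies within the scatter of it, while compound 1 lies beyond the scatter, well below. Compound 4, `COc1cccc(N(C)/C(S)=C2/C(=O)c3cc(Cl)ccc3N(C)C2=O)c1`, has the same atoms as compound 3, joined differently: 3-methoxyphenyl in place of 4-methoxyphenyl on an amine nitrogen. Among the compounds with values here, the only step between measured compounds that differ in one place, a number 3 percentage points lower from compound 2 to compound 3 (within the scatter), adds a methoxy rather than relocating one, so it bears on the present change only loosely, and it was within the scatter. Within the data shown here, with no closer precedent, no step beyond the scatter is expected in this assay, and compound 4 is therefore estimated at 92%, between 75% and 100%, which means an expected step of a number 5 percentage points lower from compound 3 to compound 4 (within the scatter).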

Compound 4, a percentage reported as inhibition, in the whole organism at one dose (the size of the read-out at that dose, not a potency): 74%
The estimate for compound 4 lay 18 percentage points above the measured number, and the stated range ends above it.
By their numbers in this assay, from the lowest: compounds 1 and 4 (each within the scatter of the next); then compounds 3 and 2 (each within the scatter of the next).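

Moving the methoxy on the phenyl ring matters in this assay: 3-methoxyphenyl in place of 4-methoxyphenyl on the amine nitrogen gives a number 23 percentage points lower from compound 3 to compound 4 (beyond the scatter) and lies beyond the scatter. Adding a methoxy to the phenyl ring is therefore not neutral in itself, since the 3-methoxyphenyl group gives a number 26 percentage points lower from compound 2 to compound 4 (beyond the scatter), while the earlier 4-methoxyphenyl step stayed within the scatter. Nothing measured here explains this difference.

Still open, from the compounds shown here alone, is whether a different group on the phenyl ring, such as a hydroxy or a fluorine, would follow the methoxy. The compounds shown also leave open whether a longer ether, such as ethoxy, would behave the same way.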